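Swapping isopropyl for ethoxycarbonyl on a phenylurea

This account rests on a few compounds, and the source may have more. Where it says the series, first, only, none or still open, it means among the compounds named here.

Of the compounds shown here, two of a phenylurea series have been tested in an ADME assay on the whole organism with Oryza sativa as the target, tested at 10 uM; on this read-out higher numbers stand for a weaker effect at the one concentration tested and lower numbers for a stronger effect. Compound 1 `CC(C)c1cccc(NC(=O)N[C@@H](C)c2ccccc2)c1` gives 86% in this assay. Compound 2 `CC(C)c1ccc(NC(=O)N[C@H](C)c2ccccc2)cc1`, which carries the same isopropyl group, gives 49%. Among the measured compounds shown here, compound 2 thus stands at the lowest of the two numbers, and its only neighbour, compound 1, lies a large distance higher, a gap that is beyond the usual scatter. Compound 2 is therefore the one with the stronger effect among the pair.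

The next compound, compound 3 `CCOC(=O)c1ccc(NC(=O)N[C@H](C)c2ccccc2)cc1`, differs from compound 2 in one place: ethoxycarbonyl in place of isopropyl on an aromatic carbon. For the measured compounds named here, no measured pair shows this exact exchange, so there is no measured step to lean on. Going by the values given here, the only guide is that compound 2 sits well apart from compound 1. Compound 3 is expected to move upward by a modest amount, estimated as a number 11 percentage points higher from compound 2 to compound 3 (beyond the scatter) in this assay, a step of roughly the size of the scatter rather than clearly beyond it. The expected value for compound 3 is therefore 60%, with a range from 35% to 90%.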

Compound 3, a percentage reported as activity, at one concentration (the size of the read-out at that concentration, not a potency): 92%
Compound 3: middle estimate off by 32 percentage points, on the low side; the measured number lies above the stated range.
By their numbers in this assay, from the lowest: compound 2; then compounds 1 and 3 (each within the scatter of the next).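

In this assay, among the compounds shown here, ethoxycarbonyl in place of isopropyl on an aromatic carbon para to a large group gives a number 43 percentage points higher from compound 2 to compound 3 (beyond the scatter) and provides the first direct look at a single change. Since higher numbers stand for a weaker effect here, this position is clearly sensitive to the group it carries, and the isopropyl of compound 2 goes with the stronger effect in this pair. The exchange alters several things at once, replacing 3 heavy atoms and 0 hydrogen-bond acceptors with 5 heavy atoms and 2 hydrogen-bond acceptors, and no measurement shown here links any of these differences to the result.

From the compounds shown here alone, a single pair cannot separate the contribution of size from that of the added oxygen atoms, so it remains open where a group such as methyl, an amine or a carboxylic acid would fall at this position. Going by these compounds, it is also open whether a longer alkyl chain would stay close to compound 2 or move toward compound 3, and whether ethoxycarbonyl would have a similar effect on another core.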